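This account rests on a few compounds, and the source may have more. Where it says the series, first, only, none or still open, it means among the compounds named here.

Compound 3 `Cc1ccccc1-c1ccc(-c2nnc(N(C)Cc3ccc4nccn4c3)o2)cc1` gives the lowest number of the two figures reported in an assay on isolated protein for inhibition of tyrosine-protein kinase receptor UFO (Homo sapiens), read by LC-MS (a lower number here means a stronger inhibitor, a higher number a weaker inhibitor), with 631 nM. In this assay compound 2 `CN(Cc1ccc2nccn2c1)c1nnc(-c2ccc(-c3ccccc3C#N)cc2)o1` gives 3980 nM. Compound 1 `CN(Cc1ccc2nccn2c1)c1nnc(-c2ccccc2)o1` reaches only a limit in this assay, > 100000 nM, which is not a number (the limit of > 100000 nM in this assay, at which 1 of the 3 values shown sits). Compound 4 `Cc1noc(C)c1-c1ccc(-c2nnc(N(C)Cc3ccc4nccn4c3)o2)cc1` carries 3,5-dimethyl-1,2-oxazol-4-yl in place of 2-methylphenyl on an aromatic carbon. The closest guide is a 6.3-fold lower number from compound 2 to compound 3 (0.80 log units; beyond the scatter), where cyano gave way to methyl, while an at least 25-fold lower number from compound 1 to compound 2 (1.40 log units; beyond the scatter) and an at least 150-fold lower number from compound 1 to compound 3 (2.19 log units; beyond the scatter) show that adding an aromatic ring there counts for much. Compound 4 keeps an aromatic ring at that place but brings one with hetero atoms, so a modest rise in the number is expected, a 2.5-fold higher number from compound 3 to compound 4 (0.40 log units; beyond the scatter). Compound 4 is therefore estimated at 1600 nM, with a range from 400 nM to 6300 nM.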

Compound 4, half-maximal inhibitory concentration: 31600 nM
Estimate against measurement, compound 4: 20-fold (1.30 log units) below; the whole stated range lies below it.
By their numbers in this assay, from the lowest: compound 3; then compound 2; then compound 4. At a limit, above all of these: compound 1.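

Replacing 2-methylphenyl with 3,5-dimethyl-1,2-oxazol-4-yl, which has the same heavy-atom count, shows that in this assay not every aromatic ring serves equally at this place (a 50-fold higher number from compound 3 to compound 4 (1.70 log units; beyond the scatter)). The same group also falls behind 2-cyanophenyl (a 7.9-fold higher number from compound 2 to compound 4 (0.90 log units; beyond the scatter)), yet it still improves on hydrogen (an at least 3.1-fold lower number from compound 1 to compound 4 (0.50 log units; beyond the scatter)). That last step rests on a limit for compound 1, not a number: (the limit of > 100000 nM in this assay, at which 1 of the 4 values shown sits).

The compounds shown do not separate the roles of the hetero atoms, the five-membered ring and the two methyl groups. From the compounds shown here alone, how a pyridine ring or an unsubstituted phenyl ring would stand at this place remains open.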